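Adding a Phenyl Group to Compound 2

The source may report more compounds than this note shows. Statements on the series, on what has been measured and on what is new or still open speak of the compounds shown alone.

Measured compounds:
compound 1, `O=C(CCCCC1CCSS1)NCc1cn(CCCCOc2ccc3ccc(=O)oc3c2)nn1` — 40.5%
compound 2, `O=C(CCCCC1CCSS1)NCc1cn(CCCCCOc2ccc3ccc(=O)oc3c2)nn1` — 46.3%

Of the compounds shown here, two have been measured in a functional assay on PC-12 cells (Rattus norvegicus) for cytotoxicity, read by MTT assay, with stated times of 3 h and 2 h, tested at 0.1 uM; a lower number here means a weaker effect, a higher number a stronger effect of the compound at the concentration tested. Compound 1 gives 40.5%, and compound 2 gives 46.3%. For the measured compounds named here, compound 2 thus stands with the larger of the two numbers, but the gap to compound 1 lies within the usual scatter of this assay, so the two cannot be set apart; no step between them has been computed, and only their two values are known.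

Compound 3, `O=C(CCCCC1CCSS1)NCc1cn(CCCCCOc2ccc3cc(-c4ccccc4)c(=O)oc3c2)nn1`, has not yet been measured. It differs from compound 2 in one place: phenyl in place of hydrogen on an aromatic carbon. Going by the values given here, no measured pair shows the effect of such a change, so there is no basis for expecting a step beyond the scatter. The step from compound 2 to compound 3 is therefore expected to be small, a number 1.7 percentage points higher from compound 2 to compound 3 (within the scatter), in either direction or none at all. On that basis compound 3 is estimated at 48%, within a range from 30% to 68%.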

Compound 3, a percentage reported as activity, at one concentration (the size of the read-out at that concentration, not a potency): 35.5%
Compound 3: the middle estimate sits 12.5 percentage points above what was measured; measured number inside the range.
By their numbers in this assay, from the lowest: compounds 3, 1 and 2 (each within the scatter of the next, the first and the last beyond it).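

Putting phenyl in place of hydrogen on this aromatic carbon, two atoms from the ring oxygen, gives a number 10.8 percentage points lower from compound 2 to compound 3 (beyond the scatter) in this assay. For the compounds shown here, this is the first evidence that this carbon, which carries hydrogen in both earlier compounds, is not silent in this read-out, although the change does not abolish it, as compound 3 still gives 35.5%. No measurement at hand accounts for the step.

On these data alone, it remains open whether the step follows from the aromatic ring itself, since a methyl group, an amine or a carboxylic acid on this carbon would each put the question differently. As far as these compounds go, it is also open whether phenyl here would give a similar step on the shorter chain of compound 1, and how the step would look at other concentrations.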